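A few compounds are considered here, and "the series" means these few. Any claim that something is new, unique, unknown or untested is made for them only; others in the source may bear on it.

Of the compounds shown here, three share one core and have been measured in a physicochemical assay for lipophilicity, using the shake flask method, measured as octanol-water partition, at pH 7.4; on this read-out higher numbers stand for higher lipophilicity and lower numbers for lower lipophilicity. Compound 1 `COc1cc(/C=C/C(=O)Nc2ccccc2)ccc1OCCCN1CCCCC1` gives 1.58 in this assay, and compound 2 `CCN(CC)CCCCOc1ccc(/C=C/C(=O)Nc2ccccc2)cc1OC` gives 1.59. Compound 3 `COc1cc(/C=C/C(=O)Nc2ccccc2)ccc1O`, which carries only a hydrogen on the oxygen on the aromatic ring, gives 1.42; it has the lowest of the three numbers, yet both other values lie within the scatter of it, so the three cannot be told apart on this assay.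

Compound 4 `COc1cc(/C=C/C(=O)Nc2ccccc2)ccc1OCCCCCN1CCCC1` is the next compound, not yet measured. It differs from compound 3 in one place: 5-(pyrrolidin-1-yl)pentyl in place of hydrogen on an oxygen on an aromatic ring.

The two measured steps that bear on this change run the other way round, from a chain-bearing compound to compound 3. Going a number 0.16 log units lower from compound 1 to compound 3 (within the scatter) and a number 0.17 log units lower from compound 2 to compound 3 (within the scatter), removing such a chain altered the number only within the scatter. Putting a chain of this kind back on is therefore expected to shift this assay by no more than the scatter, if at all, with a small rise as the likelier direction; the expected step is a number 0.20 log units higher from compound 3 to compound 4 (within the scatter). Compound 4 is accordingly estimated at 1.62, with a range from 1.3 to 1.95.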

Compound 4, partition coefficient: 1.64
Beside the measured number, compound 4's estimate is 0.02 log units below it; low and high end bracket the measured number.
By their numbers in this assay, from the lowest: compounds 3, 1, 2 and 4 (each within the scatter of the next).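

Attaching 5-(pyrrolidin-1-yl)pentyl to the oxygen on the aromatic ring gives a number 0.22 log units higher from compound 3 to compound 4 (within the scatter) in this assay and so extends the earlier picture: a third chain, with a different length and a different ring at its end, can occupy this oxygen without a step beyond the scatter. Changing the chain end also leaves the read-out within the scatter, with a number 0.05 log units higher from compound 2 to compound 4 (within the scatter) and a number 0.06 log units higher from compound 1 to compound 4 (within the scatter) as the two comparisons, so compounds 1, 2 and 4 cannot be told apart on this assay. No independent information is available to explain why these chains behave alike.

A chain ending in a carboxylic acid, or a plain pentyl chain with no amine at its end, could behave differently on this oxygen. The compounds shown do not settle whether either would stay within the scatter.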